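Swapping the Aryl Group on the Shared Core

This account rests on a few compounds, and the source may have more. Where it says the series, first, only, none or still open, it means among the compounds named here.

Three compounds share one core and differ only in the aromatic group on a nitrogen on an aromatic ring. Compound 1 `Cc1cc(F)cc(Nc2cc(NC(=O)Nc3c(Cl)cccc3Cl)ncn2)c1` is measured in a functional assay on NCI-H226 cells (Homo sapiens) for inhibition, read by MTT assay, with a stated time of 48 h, tested at 10 uM (a lower number here means less inhibition, a higher number more inhibition at the concentration tested (going by the name of the read-out)), and gives 78.1%. Compound 2 `COc1ccc(Nc2cc(NC(=O)Nc3c(Cl)cccc3Cl)ncn2)cc1C` gives 50% in this assay, and compound 3 `O=C(Nc1cc(Nc2ccc(F)c(Cl)c2)ncn1)Nc1c(Cl)cccc1Cl` gives 47.3%. Compound 3 thus holds the lowest of the three numbers; its gap to compound 2 lies within the scatter, while compound 1 stands beyond it.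

The steps already measured all touch the same place. From compound 1 the read-out fell in a number 28.1 percentage points lower from compound 1 to compound 2 (beyond the scatter) and in a number 30.8 percentage points lower from compound 1 to compound 3 (beyond the scatter), whereas a number 2.7 percentage points lower from compound 2 to compound 3 (within the scatter) stayed within the scatter. Compound 4 `CCc1ccc(Nc2cc(NC(=O)Nc3c(Cl)cccc3Cl)ncn2)cc1` continues this series: 4-ethylphenyl in place of 3-chloro-4-fluorophenyl on a nitrogen on an aromatic ring. Among the measured compounds shown here, no measured step exchanges a halogen-bearing phenyl for one bearing only carbon, so the closest guide is that compound 2, whose phenyl carries a methyl among its groups, sits within the scatter of compound 3. A step of a number 7.7 percentage points higher from compound 3 to compound 4 (within the scatter) is therefore expected, meaning little change beyond the scatter, with wide uncertainty. Compound 4 is estimated at 55%, in the range 35% to 75%.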

Compound 4, a percentage reported as inhibition, at one concentration (the size of the read-out at that concentration, not a potency): 39.5%
Beside the measured number, compound 4's estimate is 15.5 percentage points above it, within the range that was stated.
By their numbers in this assay, from the lowest: compounds 4, 3 and 2 (each within the scatter of the next, the first and the last beyond it); then compound 1.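

Seen in this assay, the change at this position on a nitrogen on an aromatic ring gives a number 7.8 percentage points lower from compound 3 to compound 4 (within the scatter) when an all-carbon 4-ethylphenyl of the same heavy-atom count replaces the halogen-bearing 3-chloro-4-fluorophenyl, so removing both halogens in this one exchange leaves no separable change in the read-out. The same group does separate from 4-methoxy-3-methylphenyl, with a number 10.5 percentage points lower from compound 2 to compound 4 (beyond the scatter) as the printed step, although that step is modest and compound 2 and compound 3 lie within the scatter of each other. The widest gap so far is a number 38.6 percentage points lower from compound 1 to compound 4 (beyond the scatter) in favour of 3-fluoro-5-methylphenyl, and since compound 3 also carries fluorine while compound 2 and compound 4 carry none, the presence of halogen does not by itself sort these four compounds.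

Going by these compounds, it remains open whether an amine or a carboxylic acid on the phenyl ring, or a chain longer than ethyl, would stay near compound 4 or approach compound 1. Nothing available here explains why these aryl groups give different numbers.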